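This account rests on a few compounds, and the source may have more. Where it says the series, first, only, none or still open, it means among the compounds named here.

Of the compounds shown here, three have so far been measured in a functional assay on Raji cells (Homo sapiens) for cytotoxicity, read by MTT assay, with a stated time of 48 h; a lower number here means a stronger inhibitor, a higher number a weaker inhibitor. Compound 1, `O=C(O)CN1C(=O)/C(=C/c2nc3cc(Cl)ccc3n2Cc2ccccc2F)SC1=S`, gives 2780 nM. Compound 2, `O=C(O)CN1C(=O)/C(=C/c2nc3ccc(Cl)cc3n2Cc2ccccc2F)SC1=S`, is built from the same atoms as compound 1, joined differently; the difference between the two cores is not broken down here. In this assay compound 2 gives 8870 nM. Compound 3, `O=C(O)CN1C(=O)/C(=C/c2nc3cc(F)ccc3n2Cc2ccccc2F)SC1=S`, gives 20400 nM in this assay. Compound 3 arises from compound 1 by a single change, (fluoro in place of chloro on an aromatic carbon), and that change brought a 7.3-fold higher number from compound 1 to compound 3 (0.87 log units; beyond the scatter). Compound 2 thus holds the second highest of the three numbers, with compound 3 its nearest neighbour and compound 1 its furthest.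

Compound 4, `O=C(O)CN1C(=O)/C(=C/c2nc3ccc(F)cc3n2Cc2ccccc2F)SC1=S`, has not yet been measured. It arises from compound 2 by fluoro in place of chloro on an aromatic carbon, and since the place is described in exactly the same words as for the pair above, this is the same change, occurring in two pairs of the compounds shown. In this assay the step is expected to be a 5.6-fold higher number from compound 2 to compound 4 (0.75 log units; beyond the scatter), of similar direction and size to the measured one, because the earlier change gave a 7.3-fold higher number from compound 1 to compound 3 (0.87 log units; beyond the scatter). That expectation rests on a single measured example on a different core, so it is held loosely. Compound 4 is therefore estimated to give about 50000 nM in this assay, with a plausible range from 15000 nM to 150000 nM.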

Compound 4, half-maximal inhibitory concentration: 22400 nM
For compound 4 the middle estimate is 2.2-fold (0.35 log units) above the measured one; the range from low to high includes it.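

In this assay, fluoro in place of chloro on an aromatic carbon again gave a weaker compound, with a 2.5-fold higher number from compound 2 to compound 4 (0.40 log units; beyond the scatter) as the new step, so the direction of the change held on both cores shown. The size of the step did not carry over, since the two steps stand apart by more than the scatter expected of such a pair:
the same change on two cores in this assay, a 7.3-fold higher number (0.87 log units; beyond the scatter) from compound 1 to compound 3 and a 2.5-fold higher number (0.40 log units; beyond the scatter) from compound 2 to compound 4, 2.9-fold (0.46 log units) apart, beyond the scatter of two such steps
For this series, the direction of the earlier step was therefore a better guide than its size, and a step measured on one core can be carried to the other only as a rough indication of how far the number will move. Among these compounds, with only two pairs, however, this does not show why the size differs or whether the same direction would appear on any further core.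

The compounds shown carry only chloro or fluoro on this ring, so it remains open how bromo, methyl or methoxy in the same places would compare on either core. From the compounds shown here alone, it also remains open whether the step would keep its direction if the carboxylic acid gave way to an ester or an amide, or if the fluorine on the benzyl ring gave way to chlorine.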